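From 4-methoxyphenyl to 3-fluorophenyl at the assay limit

The source may hold more compounds than are shown below. What is called first, only, known or untested is meant among the compounds shown, and "the series" means these compounds.

Of the compounds shown here, three sharing one core have been tested in a functional assay on DU-145 cells (Homo sapiens) for antiproliferative activity, read by MTT assay, with a stated time of 48 h (a lower number here means a stronger inhibitor, a higher number a weaker inhibitor), and only one of them gives a number. Compound 1 `C/C(=C\CC/C(C)=C/CC[C@@H]1[C@@]2(C)CCC(=O)C(C)(C)[C@H]2CC[C@@]1(C)O)CC/C=C(\C)C(=O)OCc1cn(-c2ccc(F)cc2)nn1` gives > 150000 nM here, which is a limit. Compound 2 `C/C(=C\CC/C(C)=C/CC[C@@H]1[C@@]2(C)CCC(=O)C(C)(C)[C@H]2CC[C@@]1(C)O)CC/C=C(\C)C(=O)OCc1cn(-c2cccc(Br)c2)nn1` gives > 150000 nM here, which is also a limit. For the measured compounds named here, compound 3 `COc1ccc(-n2cc(COC(=O)/C(C)=C/CC/C(C)=C/CC/C(C)=C/CC[C@@H]3[C@@]4(C)CCC(=O)C(C)(C)[C@H]4CC[C@@]3(C)O)nn2)cc1` gives 135000 nM and is the only compound with a true number. The series is thus marked by the limit of > 150000 nM in this assay, at which 2 of the 3 values shown sit, in its readings so far.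

Compound 4 `C/C(=C\CC/C(C)=C/CC[C@@H]1[C@@]2(C)CCC(=O)C(C)(C)[C@H]2CC[C@@]1(C)O)CC/C=C(\C)C(=O)OCc1cn(-c2cccc(F)c2)nn1` has 3-fluorophenyl in place of 4-methoxyphenyl on an aromatic nitrogen, a change counted as 3-fluorophenyl in place of 4-methoxyphenyl on an aromatic nitrogen here.

Going by the values given here, two measured steps bear on this change, as both alter the same aryl group: an at least 1.1-fold lower number from compound 1 to compound 3 (0.04 log units; that floor lies within the scatter) and an at least 1.1-fold lower number from compound 2 to compound 3 (0.04 log units; that floor lies within the scatter) here. Neither floor shows a step beyond the scatter, so none is expected in this assay for this change. The expected change is a 1.1-fold higher number from compound 3 to compound 4 (0.05 log units; within the scatter) in this case. For compound 4 the estimate is 150000 nM, with an expected range from 100000 nM to 220000 nM, and a report as a limit is also expected to be likely.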

Compound 4, half-maximal inhibitory concentration: > 150000 nM
Compound 4 gave a limit, no number; the forecaster's own chance of this, stated with the estimate: 70%; the middle value lies on the limit itself.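

In this assay, 3-fluorophenyl in place of 4-methoxyphenyl on the aromatic nitrogen gives an at least 1.1-fold higher number from compound 3 to compound 4 (0.04 log units; that floor lies within the scatter), so this direct comparison shows no step beyond the usual scatter and puts no upper bound on the change. The steps joining compound 4 to compound 1 and compound 2 cannot be read, as each has a limit at both ends, so moving the fluoro group or exchanging it for bromo has no measurable size here. All three halogen-bearing aryl groups now sit at one limit, and compound 3 alone gives a true number: the limit of > 150000 nM in this assay, at which 3 of the 4 values shown sit.

The compounds shown leave open whether any group on this aromatic nitrogen can give a number clearly lower than that of compound 3. An aminophenyl or a carboxyphenyl group there would put that question to the test.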